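From Bromo to Methoxy on a Shared Core

A few compounds are considered here, and "the series" means these few. Any claim that something is new, unique, unknown or untested is made for them only; others in the source may bear on it.

In a functional assay (Nicotiana tabacum) (a lower number here means a stronger inhibitor, a higher number a weaker inhibitor), compound 1 `CSc1nc(Nc2ccc(F)cc2)c2cccnc2n1` gives 2620 nM, while compound 2 `CSc1nc(Nc2ccc(Br)cc2)c2cccnc2n1` gives 5750 nM, the higher of the two numbers. Compound 3 `COc1ccc(Nc2nc(SC)nc3ncccc23)cc1` has methoxy in place of bromo on an aromatic carbon, (methoxy in place of bromo on an aromatic carbon). Going by the values given here, the only measured guide is modest: a 2.2-fold higher number from compound 1 to compound 2 (0.34 log units; beyond the scatter). Among the compounds with values here, no measured compound carries methoxy, so only a small move toward a lower number is expected, and it may not clear the scatter. The expected change is a 1.5-fold lower number from compound 2 to compound 3 (0.18 log units; within the scatter). For compound 3 the estimate is 3800 nM, with an expected range of 1500 nM to 10000 nM.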

Compound 3, half-maximal inhibitory concentration: 9420 nM
The estimate for compound 3 lay 2.5-fold (0.39 log units) below the measured number; low and high end bracket the measured number.
By their numbers in this assay, from the lowest: compound 1; then compounds 2 and 3 (each within the scatter of the next).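

In this assay, methoxy in place of bromo on this aromatic carbon leaves the number within the scatter (a 1.6-fold higher number from compound 2 to compound 3 (0.21 log units; within the scatter)), so these two groups cannot be told apart here. Methoxy in place of fluoro, at the same position, gives a step beyond the scatter (a 3.6-fold higher number from compound 1 to compound 3 (0.56 log units; beyond the scatter)), which leaves fluoro with the lowest number of the three groups shown. Nothing available accounts for these differences. On these data alone, whether an amine, a carboxylic acid or a longer chain at this position would lower the number remains open, as does whether any group here improves on fluoro.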